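A few compounds are considered here, and "the series" means these few. Any claim that something is new, unique, unknown or untested is made for them only; others in the source may bear on it.

Measured so far in a functional assay on A549 cells (Homo sapiens) for antiproliferative activity, read by MTT assay, with a stated time of 48 h; on this read-out lower numbers stand for stronger inhibition and higher numbers for weaker inhibition:
Compound 1 `N#CC1=C(N)Oc2c(c3nc4ccccc4nc3c3ccccc23)C12C(=O)N(Cc1cnnn1-c1ccc(Cl)cc1)c1ccccc12`: in this assay compound 1 gives > 50000 nM, which is a limit of the assay and not a number.
Compound 2 `N#CC1=C(N)Oc2c(c3nc4ccccc4nc3c3ccccc23)C12C(=O)N(Cc1cnnn1-c1cccc(Cl)c1)c1ccccc12`: in this assay compound 2 gives 32600 nM.
Compound 3 `N#CC1=C(N)Oc2c(c3nc4ccccc4nc3c3ccccc23)C12C(=O)N(Cc1cnnn1-c1ccc(Br)cc1)c1ccccc12`: in this assay compound 3 gives 44300 nM.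

Compound 3 holds the higher of the two numbers measured, with compound 2 nearest: a 1.4-fold higher number from compound 2 to compound 3 (0.13 log units; within the scatter). Compound 1 sits at the limit (the limit of > 50000 nM in this assay, at which 1 of the 3 values shown sits), so no number can be set against it beyond an at least 1.5-fold lower number from compound 1 to compound 2 (0.18 log units; that floor lies within the scatter) and an at least 1.1-fold lower number from compound 1 to compound 3 (0.05 log units; that floor lies within the scatter), both of which only mark a floor that lies within the scatter.

Compound 4 `N#CC1=C(N)Oc2c(c3nc4ccccc4nc3c3ccccc23)C12C(=O)N(Cc1cnnn1-c1cc(Cl)ccc1Cl)c1ccccc12` differs from compound 3 by 2,5-dichlorophenyl in place of 4-bromophenyl on an aromatic nitrogen. For the measured compounds named here, the steps that bear on this are the exchanges of the aryl group on the aromatic nitrogen among compounds 1, 2 and 3; none of them moved the read-out beyond the scatter. The change to 2,5-dichlorophenyl is therefore expected to give no step beyond the scatter, a 1.1-fold lower number from compound 3 to compound 4 (0.04 log units; within the scatter), with the result likely staying in the weak range. For compound 4 the estimate is 40000 nM, with a range from 15000 nM to 90000 nM, and a fair chance that only a limit is reported.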

Compound 4, half-maximal inhibitory concentration: > 50000 nM
Compound 4: a limit, no number; the forecaster's own chance of this, stated with the estimate: 35%; middle value at least 1.2-fold (0.09 log units) from the limit.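

In this assay, for the compounds shown here, compound 4 gives > 50000 nM, which is a limit of the assay and not a number, so the 2,5-dichlorophenyl group, the first aryl group here to carry two halogens, yields no measurable gain on this aromatic nitrogen. Against the compounds with numbers only floors can be given, an at least 1.1-fold higher number from compound 3 to compound 4 (0.05 log units; that floor lies within the scatter) and an at least 1.5-fold higher number from compound 2 to compound 4 (0.18 log units; that floor lies within the scatter), and the step between the two compounds at the limit cannot be read. Across the four halogenated aryl groups shown, no readable step at this position goes beyond the scatter, and the limit now takes in a second compound: the limit of > 50000 nM in this assay, at which 2 of the 4 values shown sit.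

Going by these compounds, all four compounds carry a halogen-bearing phenyl on this aromatic nitrogen, so it remains open whether a phenyl bearing an amine or a carboxylic acid, or a longer chain in place of the aryl group, would move the read-out beyond the scatter. On these data alone, no order can be set between compound 1 and compound 4, and the effect of changes elsewhere on the shared core remains open as well.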